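Substituent changes on a shared core: compounds 1 to 4

The source may report more compounds than this note shows. Statements on the series, on what has been measured and on what is new or still open speak of the compounds shown alone.

Measured in an assay on isolated protein for inhibition of 2-Hydroxyacid oxidase 2 (Homo sapiens), tested at 1 uM; on this read-out lower numbers stand for a weaker effect and higher numbers for a stronger effect at the one concentration tested:
- compound 1 `Cc1n[nH]c(C(=O)O)c1Cc1cccc(-c2ccc(C#N)cc2)c1`: 13%
- compound 2 `Cc1n[nH]c(C(=O)O)c1Cc1cccc(C(=O)O)c1`: 3%
- compound 3 `Cc1n[nH]c(C(=O)O)c1Cc1cccc(C#N)c1`: 6%

Compound 3 stands second highest of the three numbers in this assay. Its nearest neighbour is compound 2, with a number 3 percentage points higher from compound 2 to compound 3 (within the scatter); the furthest is compound 1, with a number 7 percentage points lower from compound 1 to compound 3 (within the scatter). All three numbers sit within the scatter of one another, so no order among them can be read from these data.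

The next compound, compound 4 `Cc1n[nH]c(C(=O)O)c1Cc1cccc(OC(F)(F)F)c1`, differs from compound 3 in one place: trifluoromethoxy in place of cyano on an aromatic carbon.

Going by the values given here, no measured step exchanges a cyano for a trifluoromethoxy, so nothing bears directly on this change. The two steps that touch the same aromatic carbon, a number 7 percentage points lower from compound 1 to compound 3 (within the scatter) and a number 3 percentage points higher from compound 2 to compound 3 (within the scatter), are both within the scatter, and the third, a number 10 percentage points lower from compound 1 to compound 2 (within the scatter), is as well. Three different groups at this position have left this assay essentially flat, so a step of no size beyond the scatter is expected here either.

Compound 4 is therefore expected to give 8% in this assay, with a range from 0% to 22%. The expected step of a number 2 percentage points higher from compound 3 to compound 4 (within the scatter) is estimated to lie within the scatter.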

Compound 4, a percentage reported as inhibition, at one concentration (the size of the read-out at that concentration, not a potency): 2%
For compound 4 the middle estimate is 6 percentage points above the measured one; the range from low to high includes it.
By their numbers in this assay, from the lowest: compounds 4, 2, 3 and 1 (each within the scatter of the next, the first and the last beyond it).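

Going by these compounds alone, a step of a number 11 percentage points lower from compound 1 to compound 4 (beyond the scatter) in this assay is the first to lie beyond the scatter, and it is modest, so trifluoromethoxy and 4-cyanophenyl are the one pair of groups on this aromatic carbon that can be told apart. Against cyano and carboxy the same group shows no separation, with a number 4 percentage points lower from compound 3 to compound 4 (within the scatter) and a number 1 percentage points lower from compound 2 to compound 4 (within the scatter) both standing within the scatter, so trifluoromethoxy, with 5 heavy atoms in place of the 2 of cyano, leaves the read-out where those two groups stand. Within the data shown here, no independent measurement in hand accounts for any of these numbers, and the one step beyond the scatter remains a bare observation.

From the compounds shown here alone, whether an amine, a hydroxyl or a longer chain on this aromatic carbon would give a number clear of the scatter from all four compounds stays open. Also open, going by these compounds, is whether a phenyl ring without the cyano group, or with it at another ring carbon, would keep the small separation from compound 4, and the single tested concentration says nothing about potency.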